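Alkynyl uracil diols: from chloropropyl to tert-butyl

The source may report more compounds than this note shows. Statements on the series, on what has been measured and on what is new or still open speak of the compounds shown alone.

Measured compounds:
compound 1 `O=c1[nH]c(=O)n(CCC(CO)CO)cc1-c1ccco1` gives > 100000 nM in a functional assay on HeLa cells (Homo sapiens) for antiproliferative activity, read by MTT assay, with a stated time of 72 h (on this read-out higher numbers stand for weaker inhibition and lower numbers for stronger inhibition), a limit of the assay.
compound 2 `O=c1[nH]c(=O)n(CCC(CO)CO)cc1C#Cc1ccc(Br)cc1` gives 67700 nM in this assay.
compound 3 `O=c1[nH]c(=O)n(CCC(CO)CO)cc1C#CCCCCl` gives > 100000 nM in this assay, a limit of the assay.

Compound 3 thus stands at the limit of > 100000 nM in this assay, at which 2 of the 3 values shown sit. The step from compound 1 to compound 3 is a step that the two limits leave unreadable from compound 1 to compound 3, and from compound 2 to compound 3 it is an at least 1.4-fold higher number from compound 2 to compound 3 (0.16 log units; that floor lies within the scatter). Compound 4 `CC(C)(C)C#Cc1cn(CCC(CO)CO)c(=O)[nH]c1=O` differs from compound 3 by tert-butyl in place of 3-chloropropyl on a triple-bonded carbon. Neither measured step bears directly on this change, and both end at a limit, so no step beyond the scatter is expected from compound 3 to compound 4, a number no higher from compound 3 to compound 4 (the limit leaves the size open). Compound 4 is estimated to give 100000 nM in this assay, within 30000 nM to 300000 nM, and most likely only a limit.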

Compound 4, half-maximal inhibitory concentration: > 100000 nM
Compound 4 was reported as a limit (the forecaster's own chance of this, stated with the estimate: 70%); the middle value lies on the limit itself.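

On this triple-bonded carbon, tert-butyl now joins 3-chloropropyl at the limit in this assay, so a branched group without chlorine does not bring a compound off that limit: the limit of > 100000 nM in this assay, at which 3 of the 4 values shown sit.

Against 4-bromophenyl, the one readable step is an at least 1.4-fold higher number from compound 2 to compound 4 (0.16 log units; that floor lies within the scatter). The steps to compound 4 from compound 1 and from compound 3 cannot be read, since each joins two limits.

On these data alone, how far past the limit compound 3 and compound 4 lie remains open. So does whether an amine, a carboxylic acid or a longer chain on this triple-bonded carbon would give a measurable value.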